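This account rests on a few compounds, and the source may have more. Where it says the series, first, only, none or still open, it means among the compounds named here.

Compound 1 `O=C(NCc1ccc(S(=O)(=O)c2cccc(C(F)(F)F)c2)cc1)c1cc2cnccc2[nH]1`: 8 nM. Compound 2 `O=C(NCc1ccc(S(=O)(=O)c2cccc(C(F)(F)F)c2)cc1)c1cc2ccncc2o1`: 5 nM. Compound 3 `O=C(NCc1ccc(S(=O)(=O)N2CCCCC2)cc1)c1cc2ccncc2o1`: 40 nM.

In an assay for inhibition of Nicotinamide phosphoribosyltransferase (Homo sapiens), read by mass spectrometry, with stated times of 15 min and 30 min (a lower number here means a stronger inhibitor, a higher number a weaker inhibitor), compound 2 gives the lowest of the three numbers, yet its gap to compound 1 lies within the scatter; only compound 3 stands apart, an 8.0-fold higher number from compound 2 to compound 3 (0.90 log units; beyond the scatter). Compound 4 `O=C(NCc1ccc(S(=O)(=O)c2cccc(C(F)(F)F)c2)cc1)c1ccc2nccn2c1` keeps the sulfonyl side of compound 2 and alters the carbonyl side: a group of 9 heavy atoms (7 carbon, 2 nitrogen; one five-membered aromatic ring with 2 hetero atoms, one six-membered aromatic ring with 1 hetero atom) in place of a group of 9 heavy atoms (7 carbon, 1 nitrogen, 1 oxygen; one five-membered aromatic ring with 1 hetero atom, one six-membered aromatic ring with 1 hetero atom), on a carbonyl carbon. Among the measured compounds shown here, the one measured step that bears on such an exchange is a 1.6-fold lower number from compound 1 to compound 2 (0.20 log units; within the scatter), which stayed within the scatter. A change of similar kind and size is therefore expected to move the number in this assay little, if at all, so compound 4 is estimated to give 9 nM, with a range from 3 nM to 30 nM, meaning a 1.8-fold higher number from compound 2 to compound 4 (0.26 log units; within the scatter).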

Compound 4, half-maximal inhibitory concentration: 8 nM
The estimate for compound 4 lay 1.1-fold (0.05 log units) above the measured number, within the range that was stated.
By their numbers in this assay, from the lowest: compounds 2, 1 and 4 (each within the scatter of the next); then compound 3.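

Compound 4 shows that the carbonyl carbon also tolerates a group whose five-membered aromatic ring carries 2 hetero atoms, not only 1: in this assay there is a 1.6-fold higher number from compound 2 to compound 4 (0.20 log units; within the scatter) and no change at the digits printed from compound 1 to compound 4 (within the scatter). All three groups tried at this place, with 3-(trifluoromethyl)phenyl on the sulfonyl sulfur, thus lie within the scatter of one another. Nothing shown accounts for this tolerance.

Going by these compounds, whether it persists with piperidin-1-yl on the sulfonyl sulfur remains open. So does whether a single ring, such as pyridin-3-yl, could replace the two-ring group on the carbonyl carbon.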